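The source may hold more compounds than are shown below. What is called first, only, known or untested is meant among the compounds shown, and "the series" means these compounds.

In a functional assay on a cell-free system (plasma, Oryctolagus cuniculus) for inhibition, with stated times of 5 min, 1 min and 6 min (a higher number here means a weaker inhibitor, a lower number a stronger inhibitor), compound 1 `CCOC(=O)c1c(C)nc(-c2cccc(C#N)c2)n1OCCC(=O)O` gives > 30000 nM, which is a limit of the assay and not a number. Compound 2 `CCOC(=O)c1c(C)nc(-c2cccc(C#N)c2)n1OCc1ccccc1`, with phenyl in place of carboxymethyl, gives 5930 nM. Compound 3 `CCOC(=O)c1c(C)nc(-c2cccc(C#N)c2)n1OCc1ccc(Br)cc1`, which carries bromo in place of hydrogen on that phenyl, gives 24600 nM. This is the higher of the two true numbers, so compound 3 is the weaker inhibitor of that pair.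

Compound 4 `CCOC(=O)c1c(C)nc(-c2cccc(C#N)c2)n1OCc1ccc(OC)cc1` has not yet been measured. It has methoxy in place of the bromo of compound 3, on an aromatic carbon, para to a large group: methoxy in place of bromo on an aromatic carbon.

Among the compounds with values here, the most relevant evidence is the one measured change at this same place, where bromo replaced hydrogen and gave a 4.1-fold higher number from compound 2 to compound 3 (0.62 log units; beyond the scatter). The other two steps, an at least 5.0-fold lower number from compound 1 to compound 2 (0.70 log units; beyond the scatter) and an at least 1.2-fold lower number from compound 1 to compound 3 (0.08 log units; that floor lies within the scatter), exchange a much larger piece and bear on this question only loosely. Within the data shown here, no methoxy compound has been measured yet, so its effect remains open. Since the bromo step a 4.1-fold higher number from compound 2 to compound 3 (0.62 log units; beyond the scatter) was modest, a similarly modest or smaller fall in the number is expected, towards compound 2. The expected step is a 2.1-fold lower number from compound 3 to compound 4 (0.31 log units; beyond the scatter). For compound 4, the estimated value is 12000 nM, with a likely range from 5000 nM to 28000 nM.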

Compound 4, half-maximal inhibitory concentration: 6830 nM
Beside the measured number, compound 4's estimate is 1.8-fold (0.24 log units) above it; measured number inside the range.
By their numbers in this assay, from the lowest: compounds 2 and 4 (each within the scatter of the next); then compound 3. At a limit, above all of these: compound 1.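

Within the data shown here, at this place, para to a large group, the earlier compounds showed only that bromo gave a higher number than hydrogen. Methoxy in place of bromo gives a 3.6-fold lower number from compound 3 to compound 4 (0.56 log units; beyond the scatter), so the rise seen with bromo is not shared by every group placed here. Methoxy in place of hydrogen gives a 1.2-fold higher number from compound 2 to compound 4 (0.06 log units; within the scatter), so in this assay adding this group at this place makes no readable difference, and the position can carry a substituent with no measurable change in the number. The 4-methoxyphenyl in place of carboxymethyl gives an at least 4.3-fold lower number from compound 1 to compound 4 (0.64 log units; beyond the scatter), which is a floor and not a true size, as one end of that step is a limit: the limit of > 30000 nM in this assay, at which 1 of the 4 values shown sits.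

The compounds shown compare only hydrogen, methoxy and bromo at this place, which leaves open whether the higher number is particular to bromo or would also appear with chloro or another halogen. Going by these compounds, it also remains open how an amine or a hydroxyl would read at this same carbon, and whether a longer chain between the oxygen and the phenyl ring would change the number.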